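Cyclopropyl in place of trifluoromethyl on the shared core

This account rests on a few compounds, and the source may have more. Where it says the series, first, only, none or still open, it means among the compounds named here.

Measured in a physicochemical assay for lipophilicity, at pH 7.4; on this read-out lower numbers stand for lower lipophilicity and higher numbers for higher lipophilicity
- compound 1 `CN(C)C(=O)C1CCN(c2cnccc2-n2cccn2)CC1` gives 1.1
- compound 2 `CN(C)C(=O)C1CCN(c2cnccc2-n2cc(Br)cn2)CC1` gives 2.1
- compound 3 `CN(C)C(=O)C1CCN(c2cnccc2-n2cc(C(F)(F)F)cn2)CC1` gives 2.1

Compound 3 stands level with compound 2, together the highest of the three numbers, and clear of compound 1. Compound 4 `CN(C)C(=O)C1CCN(c2cnccc2-n2cc(C3CC3)cn2)CC1` carries cyclopropyl in place of trifluoromethyl on an aromatic carbon. Among the compounds with values here, three measured steps bear on this. Replacing hydrogen gave modest steps, a number 1.00 log units higher from compound 1 to compound 2 (beyond the scatter) and a number 1.00 log units higher from compound 1 to compound 3 (beyond the scatter), while trifluoromethyl in place of bromo gave no change at the digits printed from compound 2 to compound 3 (within the scatter). Cyclopropyl itself is untested, but with two different groups there giving alike, no step beyond the scatter is expected. The expected step is no change at the digits printed from compound 3 to compound 4 (within the scatter). The estimated value for compound 4 is 2.1, with an expected range of 1.7 to 2.5.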

Compound 4, distribution coefficient: 2.1
For compound 4 middle estimate and measured number coincide at the digits printed; measured number inside the range.
By their numbers in this assay, from the lowest: compound 1; then compounds 2, 3 and 4 (each within the scatter of the next).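

In this assay, a third group on this aromatic carbon falls in with the other two: the read-out shows no change at the digits printed from compound 3 to compound 4 (within the scatter) and no change at the digits printed from compound 2 to compound 4 (within the scatter), alongside a number 1.00 log units higher from compound 1 to compound 4 (beyond the scatter). Cyclopropyl, made of carbon only and carrying a three-membered ring, thus stands level with both bromo and trifluoromethyl, and all three stand clear of hydrogen. Nothing at hand explains why these groups read alike.

On these data alone, whether an amine or a carboxylic acid at this position would stay level with these three or fall nearer compound 1 remains open. So does the reading for a longer chain.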